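Methyl to tert-butyl on the aryl ring: working notes

This account rests on a few compounds, and the source may have more. Where it says the series, first, only, none or still open, it means among the compounds named here.

Measured so far:
compound 1 `O=C1C=CC(OCC(F)(F)F)N1c1cc(F)cc(F)c1` — 8460 nM
compound 2 `Cc1ccc(N2C(=O)C=CC2OCC(F)(F)F)cc1` — 9380 nM
compound 3 `O=C1C=CC(OC(C(F)(F)F)C(F)(F)F)N1c1ccc(Cl)cc1` — 1890 nM

In a functional assay on HeLa cells (Homo sapiens) for inhibition (a higher number here means a weaker inhibitor, a lower number a stronger inhibitor), compound 2 gives 9380 nM, the highest of the three numbers, though its gap to compound 1 lies within the scatter. Compound 3 sits clearly lower, beyond the scatter, and differs from compound 2 in more than one place, so no single step can be read from that pair. Compound 4 `CC(C)(C)c1ccc(N2C(=O)C=CC2OCC(F)(F)F)cc1` differs from compound 2 by tert-butyl in place of methyl on an aromatic carbon. Going by the values given here, no measured pair shows this change, so its size is unknown; a step within the scatter, or a small drop in the number, is expected. The estimate for compound 4 is 6000 nM, with a range from 2500 nM to 15000 nM, which corresponds to an expected step of a 1.6-fold lower number from compound 2 to compound 4 (0.19 log units; within the scatter) in this assay.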

Compound 4, half-maximal inhibitory concentration: 18100 nM
For compound 4 the middle estimate is 3.0-fold (0.48 log units) below the measured one; the whole stated range lies below it.
By their numbers in this assay, from the lowest: compound 3; then compounds 1, 2 and 4 (each within the scatter of the next, the first and the last beyond it).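

Going by these compounds alone, the step of a 1.9-fold higher number from compound 2 to compound 4 (0.29 log units; within the scatter) in this assay is the first single-place comparison. It stays within the scatter, so this position, on an aromatic carbon para to a large group, accepts tert-butyl in place of methyl with no step beyond the scatter. Nothing at hand bears on why the step has this size. Still open, on these data alone, is how an amine or a carboxylic acid at this position would read. Whether the aryl group or the fluorinated ether side sets the lower number of compound 3 also cannot be read from these compounds.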